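Halogen swap on a shared amide scaffold in A549 cells

The source may report more compounds than this note shows. Statements on the series, on what has been measured and on what is new or still open speak of the compounds shown alone.

Measured compounds:
Compound 1, `O=C(Nc1ccc(Oc2ccnc3[nH]ccc23)cc1)c1cc2cccnc2n(-c2ccc(Cl)cc2)c1=O`: 290 nM
Compound 2, `O=C(Nc1ccc(Oc2ccnc3[nH]ccc23)cc1)c1cc2cccnc2n(-c2ccc(Br)cc2)c1=O`: 280 nM
Compound 3, `Cn1ccc2c(Oc3ccc(NC(=O)c4cc5cccnc5n(-c5ccc(Cl)cc5)c4=O)cc3F)ccnc21`: 350 nM

Compounds 1, 2 and 3 were tested in a functional assay on A549 cells (Homo sapiens) for antiproliferative activity, read by MTT assay, with a stated time of 72 h; a higher number here means a weaker inhibitor, a lower number a stronger inhibitor. Compound 1 gives 290 nM there, and compound 2 gives 280 nM. Compound 2 carries one change from compound 1, (bromo in place of chloro on an aromatic carbon), and the step it made is a 1.0-fold lower number from compound 1 to compound 2 (0.02 log units; within the scatter). Compound 3 gives 350 nM in this assay; how its core differs from that of compound 1 is not broken down here.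

Compound 4, `Cn1ccc2c(Oc3ccc(NC(=O)c4cc5cccnc5n(-c5ccc(Br)cc5)c4=O)cc3F)ccnc21`, has not yet been measured. It carries the same change relative to compound 3, (bromo in place of chloro on an aromatic carbon). Since that change between compound 1 and compound 2 produced a 1.0-fold lower number from compound 1 to compound 2 (0.02 log units; within the scatter), compound 4 is expected to sit close to compound 3, with an estimated step of a 1.0-fold lower number from compound 3 to compound 4 (0.01 log units; within the scatter). The estimate for compound 4 in this assay is 340 nM, expected between 170 nM and 680 nM.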

Compound 4, half-maximal inhibitory concentration: 390 nM
Beside the measured number, compound 4's estimate is 1.1-fold (0.06 log units) below it, and the stated range covers the measured number.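

In this assay, the change from 4-chlorophenyl to 4-bromophenyl on the second core gave a step of a 1.1-fold higher number from compound 3 to compound 4 (0.05 log units; within the scatter). Set beside the earlier step, the same change shows no difference between the two cores that stands clear of the scatter: the same change on two cores in this assay, a 1.0-fold lower number (0.02 log units; within the scatter) from compound 1 to compound 2 and a 1.1-fold higher number (0.05 log units; within the scatter) from compound 3 to compound 4, 1.2-fold (0.06 log units) apart, within the scatter of two such steps. This shows that, on these two cores, the swap leaves the number within the scatter, but two pairs do not show that this would hold on any other core or that the two halogens are interchangeable elsewhere.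

The compounds shown leave open whether any other group in that place, such as a methoxy, an amine or a carboxylic acid, would move the number at all.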